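The source may report more compounds than this note shows. Statements on the series, on what has been measured and on what is new or still open speak of the compounds shown alone.

Measured so far:
compound 1 `CC(=O)N1N=C(c2ccc(C)cc2)CC1c1cn(-c2ccccc2)nc1-c1ccc(Cl)c(Cl)c1`: 70.3%
compound 2 `Cc1ccc(C2=NNC(c3cn(-c4ccccc4)nc3-c3ccc(Cl)c(Cl)c3)C2)cc1`: 48.4%
compound 3 `CC(=O)N1N=C(c2ccc(Cl)cc2)CC1c1cn(-c2ccccc2)nc1-c1ccc(Cl)c(Cl)c1`: 66.4%

In a functional assay on the whole organism (strain Wistar) for inhibition, with Rattus norvegicus as the target, read by paw edema, with stated times of 30 min and 120 min, at a dose of 50 mg/kg by the oral route (on this read-out lower numbers stand for less inhibition and higher numbers for more inhibition at the one dose given (going by the name of the read-out)), compound 1 gives 70.3%, compound 2 gives 48.4% and compound 3 gives 66.4%. The change from compound 1 to compound 2 is hydrogen in place of acetyl on an amine nitrogen in a ring; it made a number 21.9 percentage points lower from compound 1 to compound 2 (beyond the scatter). The change from compound 1 to compound 3 is chloro in place of methyl on an aromatic carbon; it made a number 3.9 percentage points lower from compound 1 to compound 3 (within the scatter).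

Compound 4 `Clc1ccc(C2=NNC(c3cn(-c4ccccc4)nc3-c3ccc(Cl)c(Cl)c3)C2)cc1` has not been measured. From compound 3 it differs by hydrogen in place of acetyl on an amine nitrogen in a ring. This is the same kind of change as from compound 1 to compound 2, not the same: there the place lies two ring bonds from the ring atom that bears a 4-methylphenyl group, here two ring bonds from the ring atom that bears a 4-chlorophenyl group. The two cores differ by chloro in place of methyl on an aromatic carbon.

For compound 4 a step of about a number 21.4 percentage points lower from compound 3 to compound 4 (beyond the scatter) in this assay is expected, beside the earlier a number 21.9 percentage points lower from compound 1 to compound 2 (beyond the scatter). This rests on compound 3 starting from 66.4% and on the core difference having given only a number 3.9 percentage points lower from compound 1 to compound 3 (within the scatter) in the acetylated pair. Compound 4 is therefore estimated at 45%, expected between 32% and 58%.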

Compound 4, a percentage reported as inhibition, in the whole organism at one dose (the size of the read-out at that dose, not a potency): 48.4%
For compound 4 the middle estimate is 3.4 percentage points below the measured one; measured number inside the range.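

In this assay, hydrogen in place of acetyl on the amine nitrogen in the ring carries over from the core bearing the 4-methylphenyl group to the core bearing the 4-chlorophenyl group, giving a number 18 percentage points lower from compound 3 to compound 4 (beyond the scatter), and the two steps agree: the same change on two cores in this assay, a number 21.9 percentage points lower (beyond the scatter) from compound 1 to compound 2 and a number 18 percentage points lower (beyond the scatter) from compound 3 to compound 4, 3.9 percentage points apart, within the scatter of two such steps

Chloro in place of methyl on the aromatic carbon gives no change at the digits printed from compound 2 to compound 4 (within the scatter), so with hydrogen on the ring nitrogen, as with acetyl, this swap leaves no reading beyond the scatter: the same change on two cores in this assay, a number 3.9 percentage points lower (within the scatter) from compound 1 to compound 3 and no change at the digits printed (within the scatter) from compound 2 to compound 4, 3.9 percentage points apart, within the scatter of two such steps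

This supports carrying the acetyl-to-hydrogen step only between these two closely related cores at the one dose given; it does not show that the step would hold on cores differing elsewhere, and it does not explain why the acetylated compounds read higher.

Still open, on these data alone, is whether a longer acyl chain, such as propanoyl, or a group such as a carboxylic acid on the ring nitrogen would match acetyl. Also open, as far as these compounds go, is how the step behaves with a methoxy group or an amine in place of the methyl or chloro on the aromatic carbon.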